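Formyl to cyanosulfanyl exchange across two cores

A few compounds are considered here, and "the series" means these few. Any claim that something is new, unique, unknown or untested is made for them only; others in the source may bear on it.

Measured so far in a functional assay on L1210 cells (Mus musculus) for cytotoxicity, with a stated time of 48 h; on this read-out higher numbers stand for weaker inhibition and lower numbers for stronger inhibition:
compound 1 `O=Cc1c(-c2ccc(Cl)cc2Cl)nc2sc(Cc3ccc(Cl)cc3)nn12` gives 82000 nM
compound 2 `O=Cc1c(-c2cc3ccccc3oc2=O)nc2sc(Cc3ccc(Cl)cc3)nn12` gives 890 nM
compound 3 `N#CSc1c(-c2ccc(Cl)cc2Cl)nc2sc(Cc3ccc(Cl)cc3)nn12` gives 49000 nM

Compound 1 and compound 3 share a core and differ in one place: cyanosulfanyl in place of formyl on an aromatic carbon. The step of a 1.7-fold lower number from compound 1 to compound 3 (0.22 log units; within the scatter) is small and lies within the scatter, so on this read-out the two are not separated. Compound 2 carries a different core; the difference between the two cores is not broken down here. Compound 2 gives the lowest number of the three, and its gaps to compound 1 and to compound 3 are both beyond the scatter.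

Compound 4 `N#CSc1c(-c2cc3ccccc3oc2=O)nc2sc(Cc3ccc(Cl)cc3)nn12` is not yet measured. It differs from compound 2 by cyanosulfanyl in place of formyl on an aromatic carbon. This is the same kind of change as that from compound 1 to compound 3, not the same: in compound 1 the changed carbon is next to the ring atom that bears a 2,4-dichlorophenyl group, while in compound 2 it is next to the ring atom that bears a large group. For the measured compounds named here, since the one measured example of this change gave a 1.7-fold lower number from compound 1 to compound 3 (0.22 log units; within the scatter), a step of similar small size is expected, a 1.5-fold lower number from compound 2 to compound 4 (0.17 log units; within the scatter), on the assumption that the exchange behaves alike on both cores, which rests on one pair only. The expected value for compound 4 in this assay is 600 nM, with a range from 200 nM to 2000 nM.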

Compound 4, half-maximal inhibitory concentration: 1300 nM
Beside the measured number, compound 4's estimate is 2.2-fold (0.34 log units) below it; low and high end bracket the measured number.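

In this assay the exchange of formyl for cyanosulfanyl on an aromatic carbon gives a 1.5-fold higher number from compound 2 to compound 4 (0.16 log units; within the scatter), so this pair is not separated on the read-out, just as the earlier pair was not. Set side by side, the two steps give no sign that the outcome of this exchange depends on the core: the same change on two cores in this assay, a 1.7-fold lower number (0.22 log units; within the scatter) from compound 1 to compound 3 and a 1.5-fold higher number (0.16 log units; within the scatter) from compound 2 to compound 4, 2.4-fold (0.39 log units) apart, within the scatter of two such steps. For the compounds shown here, this shows only that the exchange left the number within the scatter on both cores; with two pairs, it neither establishes a rule for further cores nor detects a small core-dependent difference, and the opposite directions of the two steps carry no meaning at this size.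

Going by these compounds alone, whether any group on this aromatic carbon moves the number beyond the scatter stays open, since formyl and cyanosulfanyl are the only two groups compared there, and an amine, a carboxylic acid or a longer alkyl chain in that place could behave differently. Also open is whether the formyl and cyanosulfanyl pairs stay equally close outside this one cytotoxicity read-out, as the compounds shown give numbers from a single cell assay only.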